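The source may report more compounds than this note shows. Statements on the series, on what has been measured and on what is new or still open speak of the compounds shown alone.

Compound 2, with structure `CC(C)(C)c1cc(/C=C/C(=O)NCCC2CCN(Cc3ccccc3Cl)CC2)cc(C(C)(C)C)c1O`, was tested in an assay on isolated protein for inhibition of Amine oxidase [flavin-containing] B (Homo sapiens), read by fluorescence, with stated times of 15 min and 20 min (a higher number here means a weaker inhibitor, a lower number a stronger inhibitor), and gives 9800 nM. Among the two compounds measured so far, compound 2 has the highest number, yet its only neighbour, compound 1 with structure `CC(C)(C)c1cc(/C=C/C(=O)NCCC2CCN(Cc3ccccc3F)CC2)cc(C(C)(C)C)c1O`, gives 7400 nM, and the step of a 1.3-fold higher number from compound 1 to compound 2 (0.12 log units; within the scatter) is within the scatter of repeated runs, so the two cannot be told apart on these data.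

Compound 3, with structure `CC(C)(C)c1cc(/C=C/C(=O)NCCC2CCN(Cc3ccc(C#N)cc3)CC2)cc(C(C)(C)C)c1O`, carries the change (4-cyanophenyl in place of 2-chlorophenyl on a saturated chain carbon bound to an amine nitrogen in a ring). Going by the values given here, the one measured step, a 1.3-fold higher number from compound 1 to compound 2 (0.12 log units; within the scatter), concerns a swap of one halogen for another on the same aromatic ring and showed no movement beyond the scatter. Among the compounds with values here, the change to compound 3 goes further, replacing a halogen with a nitrile and placing it as 4-cyanophenyl rather than 2-chlorophenyl; no measured pair tests that, so the expectation rests only on the small effect seen so far. A step of a 1.2-fold lower number from compound 2 to compound 3 (0.06 log units; within the scatter) is expected, in practice no movement beyond the scatter. Compound 3 is therefore expected to give about 8500 nM, between 3000 nM and 25000 nM.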

Compound 3, half-maximal inhibitory concentration: 13900 nM
Beside the measured number, compound 3's estimate is 1.6-fold (0.21 log units) below it; measured number inside the range.
By their numbers in this assay, from the lowest: compounds 1, 2 and 3 (each within the scatter of the next).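

At the place on a saturated chain carbon bound to an amine nitrogen in a ring, replacing 2-chlorophenyl with 4-cyanophenyl gives a 1.4-fold higher number from compound 2 to compound 3 (0.15 log units; within the scatter) in this assay, and replacing 2-fluorophenyl with 4-cyanophenyl gives a 1.9-fold higher number from compound 1 to compound 3 (0.27 log units; within the scatter). The earlier step only exchanged one halogen for another, whereas these steps bring in a nitrile, a different kind of group, at a different place on the phenyl ring, and the number in this assay still does not move beyond the scatter. No measured evidence is available to explain this result.

Each of these steps changes both the group and where it sits on the phenyl ring, so the compounds shown cannot separate those two changes. As far as these compounds go, it also remains open whether this place would stay just as flat with an unsubstituted benzyl, or with a phenyl ring carrying an amine or a carboxylic acid, and whether any group here can move the number beyond the scatter.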